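Swapping the amide aryl group of a GPR27 agonist

This account rests on a few compounds, and the source may have more. Where it says the series, first, only, none or still open, it means among the compounds named here.

Measured compounds:
- compound 1, `O=C(Nc1ccc(S(=O)(=O)Nc2ccccc2)cc1)c1cc(F)c(Cl)cc1F`: 37%
- compound 2, `O=C(Nc1ccc(S(=O)(=O)Nc2ccccc2)cc1)c1ccc(Cl)cc1F`: 57%

Compound 1 and compound 2 share the same core and differ only in one substituent on the ring attached to the carbonyl. In a functional assay on HEK293 cells for agonist activity at probable G-protein coupled receptor 27 (Homo sapiens), read by a luciferase reporter and beta-arrestin recruitment, with a stated time of 10 min (a lower number here means a smaller maximal response, a higher number a larger maximal response), compound 1 gives 37%, while compound 2 gives 57%. For the measured compounds named here, the single measured step is a number 20 percentage points higher from compound 1 to compound 2 (beyond the scatter). Compound 2 therefore stands highest of the two numbers, and its nearest neighbour, compound 1, lies lower by more than the scatter.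

Compound 3, `Cc1cc(Br)ccc1C(=O)Nc1ccc(S(=O)(=O)Nc2ccccc2)cc1`, changes the ring on the carbonyl carbon in two places at once: 4-bromo-2-methylphenyl in place of 4-chloro-2-fluorophenyl on a carbonyl carbon. Going by the values given here, no measured step covers a swap of the whole ring, and the one step available, a number 20 percentage points higher from compound 1 to compound 2 (beyond the scatter), shows only how much removing a single fluoro mattered there. Two substituents are exchanged here, so the outcome is uncertain. The expectation for the step from compound 2 to compound 3 in this assay is a number 2 percentage points lower from compound 2 to compound 3 (within the scatter), with no clear direction beyond the scatter. Compound 3 is expected to give about 55%, within a range from 35% to 75%.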

Compound 3, largest response reached (Emax), in percent of the reference or control that the assay uses: 103%
Estimate against measurement, compound 3: 48 percentage points below, outside the stated range (above it).
By their numbers in this assay, from the lowest: compound 1; then compound 2; then compound 3.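

In this assay, the ring on the carbonyl carbon turns out to control far more of the maximal response than the modest fluoro step, a number 20 percentage points higher from compound 1 to compound 2 (beyond the scatter), had suggested: putting 4-bromo-2-methylphenyl in place of 4-chloro-2-fluorophenyl gives a number 46 percentage points higher from compound 2 to compound 3 (beyond the scatter), a large step. The same ring in place of the 4-chloro-2,5-difluorophenyl group gives a number 66 percentage points higher from compound 1 to compound 3 (beyond the scatter), so all three compounds stand clearly apart and this position can shift the response over a wide span. Both substituents differ between compound 2 and compound 3, so the rise cannot be assigned to the bromo or to the methyl, and no measurement shown here explains it.

The 4-chloro-2-methylphenyl and 4-bromo-2-fluorophenyl groups are not among the compounds shown, and these two rings would be the ones to separate the contribution of each substituent. As far as these compounds go, it also remains open how the response would change with an amine or a carboxylic acid in place of the bromo, and whether a concentration-response potency would follow the same order as the maximal response.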